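Hydroxyethyl carbamoyl in place of piperidinylmethyl on the shared core

A few compounds are considered here, and "the series" means these few. Any claim that something is new, unique, unknown or untested is made for them only; others in the source may bear on it.

Two compounds in this series have numbers in a functional assay on LNCaP cells (Homo sapiens) for antiproliferative activity; on this read-out lower numbers stand for stronger inhibition and higher numbers for weaker inhibition. Compound 1 `CC(=O)NCC[C@@H]1C[C@@H](c2ccc(F)c(F)c2)[C@H](NC(=O)c2cc(-c3c(Cl)cnn3C)c(Cl)o2)CN1` gives 130 nM in this assay. Compound 2 `Cn1ncc(Cl)c1-c1cc(C(=O)N[C@@H]2CN[C@H](CCN3CCCCC3)C[C@H]2c2ccc(Cl)c(Cl)c2)oc1Cl` gives 1780 nM in this assay, the highest of the two numbers; its nearest neighbour is compound 1, whose number is lower by a gap beyond the scatter. Among the measured compounds shown here, no step between measured compounds that differ in a single place is available, so direct guidance for the next change is thin.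

Compound 3 `Cn1ncc(Cl)c1-c1cc(C(=O)N[C@@H]2CN[C@H](CC(=O)NCCO)C[C@H]2c2ccc(Cl)c(Cl)c2)oc1Cl` is not yet measured in this assay. It differs from compound 2 in one place: (2-hydroxyethyl)carbamoyl in place of (piperidin-1-yl)methyl on a saturated chain carbon bound to a saturated ring carbon. The entering (2-hydroxyethyl)carbamoyl resembles the chain end of compound 1, which gives 130 nM in this assay, and that is the only point of reference. A lowering beyond the scatter is expected, a 5.1-fold lower number from compound 2 to compound 3 (0.71 log units; beyond the scatter). Compound 3 is estimated at 350 nM, within a range from 100 nM to 1200 nM.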

Compound 3, half-maximal inhibitory concentration: 40 nM
For compound 3 the middle estimate is 8.8-fold (0.94 log units) above the measured one, and the stated range ends above it.
By their numbers in this assay, from the lowest: compound 3; then compound 1; then compound 2.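

In this assay, among the compounds shown here, the only single-place step is large: a 45-fold lower number from compound 2 to compound 3 (1.65 log units; beyond the scatter). This position therefore responds strongly to the group it carries, and the piperidine ring is not required for a low number, as compound 3 reaches 40 nM without it. No measurement here bears on why the change has this size.

The step replaces the ring, adds a carbonyl and adds a terminal hydroxyl all at once, so the compounds shown do not separate the share of each. Open, going by these compounds, are a methylcarbamoyl group without the hydroxyl, a carboxylic acid, a primary amine and a longer chain ending in hydroxyl on the same saturated chain carbon, any of which would show which part of (2-hydroxyethyl)carbamoyl goes with the lower number.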